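Swapping an aryl group for cyclohexyl on compound 3

This account rests on a few compounds, and the source may have more. Where it says the series, first, only, none or still open, it means among the compounds named here.

In a functional assay on HCT-116 cells (Homo sapiens) for antiproliferative activity, read by MTT assay, with a stated time of 72 h (a lower number here means a stronger inhibitor, a higher number a weaker inhibitor), the measured compounds read as follows:
Compound 1 `COc1ccc(N2C(=O)COc3ccc(-c4cnc(Cl)c(NS(=O)(=O)c5ccc(F)cc5)c4)cc32)cc1` gives 30100 nM
Compound 2 `COc1ncc(-c2ccc3c(c2)N(c2ccc(F)cc2)C(=O)CO3)cc1NS(=O)(=O)c1ccc(F)cc1` gives > 40000 nM
Compound 3 `COc1cccc(N2C(=O)COc3ccc(-c4cnc5ccccc5c4)cc32)c1` gives 8240 nM

Compound 3, at 8240 nM in this assay, has the lowest of the two true numbers, and the gap to compound 1 at 30100 nM lies beyond the usual scatter. For compound 2 the entry > 40000 nM is a limit of the assay and not a number.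

Compound 4 `O=C1COc2ccc(-c3cnc4ccccc4c3)cc2N1C1CCCCC1` has not yet been measured. It carries cyclohexyl in place of 3-methoxyphenyl on an amide-type nitrogen in a ring. Among the measured compounds shown here, the aromatic ring of carbon only thus gives way to a non-aromatic one, and the single hydrogen-bond acceptor of the group that leaves has no counterpart. For the measured compounds named here, no pair of measured compounds isolates this change, so the expectation is a loose one, starting from compound 3 at 8240 nM and leaning towards a weaker inhibitor. The expected size of the move is a 1.6-fold higher number from compound 3 to compound 4 (0.20 log units; within the scatter) in this direction, and a result within the scatter would not be surprising. For compound 4 the estimated value in this assay is 13000 nM, with an expected range from 4500 nM to 35000 nM as its upper end.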

Compound 4, half-maximal inhibitory concentration: > 40000 nM
Compound 4 gave a limit, no number (the forecaster's own chance of this, stated with the estimate: 15%); middle value at least 3.0-fold (0.48 log units) away from the limit.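

In this assay compound 4 gives > 40000 nM, which is a limit of the assay and not a number. Putting cyclohexyl in place of 3-methoxyphenyl on this amide-type nitrogen in a ring gives an at least 4.8-fold higher number from compound 3 to compound 4 (0.68 log units; beyond the scatter), the first step among the compounds shown that isolates this position and shows that the group placed there affects antiproliferative activity. The change removes the aromatic ring of carbon only and the single hydrogen-bond acceptor together, so the result cannot assign the loss to either one, and its full size cannot be read from a limit shared with another compound: the limit of > 40000 nM in this assay, at which 2 of the 4 values shown sit.

The compounds shown leave open whether plain phenyl on this nitrogen would hold the activity of compound 3, which would separate the aromatic ring from the methoxy oxygen, and whether a tetrahydropyranyl ring, non-aromatic but with an oxygen, would recover any of it. They also leave open how this position would respond to a much smaller group such as methyl, or to a benzyl group or a short chain carrying an amine.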